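The compounds below may be only part of what the source reports. "The series", "measured", "known", "first", "only" and "open" are said of these compounds alone.

In an ADME assay on MRC5 cells (Homo sapiens) for antiproliferative activity, read by MTT assay, with a stated time of 72 h (a higher number here means a weaker inhibitor, a lower number a stronger inhibitor), compound 2 `O=C1C[C@H]2O[C@H](Cc3ccccc3)[C@H](OCc3ccccc3)[C@H]2O1` gives > 100000 nM, which is a limit and not a number. Compound 1 `O=C1C[C@@H]2O[C@@H](Cc3ccccc3)[C@@H](O)[C@@H]2O1` gives > 100000 nM, also a limit. Compound 3 `O=C1C[C@H]2O[C@H](Cc3ccccc3)[C@H](O)[C@H]2O1` carries hydrogen in place of the benzyl of compound 2, on an oxygen on a saturated carbon, the change from benzyloxy to hydroxy: hydrogen in place of benzyl on an oxygen on a saturated carbon. For the measured compounds named here, no measured step gauges this change. For compound 3 no step beyond the scatter is expected in this assay because of the limit of > 100000 nM in this assay, at which 2 of the 2 values shown sit. The expected change is a number no higher from compound 2 to compound 3 (the limit leaves the size open). Compound 3 is estimated at 100000 nM, with an expected range of 30000 nM to 300000 nM.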

Compound 3, half-maximal inhibitory concentration: > 100000 nM
Compound 3: no number, only a limit (the forecaster's own chance of this, stated with the estimate: 80%); the middle value sits exactly at the limit.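

In this assay, for the compounds shown here, compound 1, compound 2 and compound 3 all give limits and not numbers, and no step among them can be read. The compounds shown leave open whether hydrogen in place of benzyl, or inversion of all stereocentres, changes the read-out at all.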